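The source may report more compounds than this note shows. Statements on the series, on what has been measured and on what is new or still open speak of the compounds shown alone.

Of the compounds shown here, two have been tested in a functional assay on Ehrlich cells (Mus musculus) for cytotoxicity, tested at 10 ug/mL; a lower number here means a weaker effect, a higher number a stronger effect of the compound at the concentration tested. Compound 1 `COc1ccc(C2C(C#N)=C(N)N(c3cc(OC)c(OC)c(OC)c3)C3=C2C(=O)CC(C)(C)C3)cc1` gives 0% there, and compound 2 `COc1cc(N2C(N)=C(C#N)C(c3ccccc3Cl)C3=C2CC(C)(C)CC3=O)cc(OC)c1OC` gives 10%. For the measured compounds named here, the two numbers lie within the scatter of each other, and the only step measured so far, a number 10 percentage points higher from compound 1 to compound 2 (within the scatter), does not rise beyond it, so neither compound can be set above the other on the numbers at hand.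

Compound 3 `COc1cc(N2C(N)=C(C#N)C(c3cccs3)C3=C2CC(C)(C)CC3=O)cc(OC)c1OC` is the next member. It differs from compound 2 in one place: thiophen-2-yl in place of 2-chlorophenyl on a saturated ring carbon. Going by the values given here, the one measured step that bears on this change is the earlier exchange of the group on the same saturated ring carbon, a number 10 percentage points higher from compound 1 to compound 2 (within the scatter), which stayed within the scatter. Among the compounds with values here, both measured compounds sit at the weak end of this assay, and nothing measured so far shows that the group on that carbon moves the read-out. Compound 3 is therefore expected to stay close to its neighbour, with a step of a number 5 percentage points lower from compound 2 to compound 3 (within the scatter) that is not expected to exceed the scatter. For compound 3 in this assay the estimate is 5%, with a range from 0% to 25%.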

Compound 3, a percentage reported as activity, at one concentration (the size of the read-out at that concentration, not a potency): 5%
Beside the measured number, compound 3's estimate shows no gap at the digits printed; the range from low to high includes it.
By their numbers in this assay, from the lowest: compounds 1, 3 and 2 (each within the scatter of the next).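

In this assay, the step of a number 5 percentage points lower from compound 2 to compound 3 (within the scatter) shows that a five-membered aromatic ring with 1 hetero atom can replace the six-membered aromatic ring of carbon only on this saturated ring carbon without a read-out change beyond the scatter, even with the chlorine gone and a hydrogen-bond acceptor counted on the entering group. For the compounds shown here, the second comparison, a number 5 percentage points higher from compound 1 to compound 3 (within the scatter), gives the same picture against 4-methoxyphenyl, so the three groups now tested on this carbon, 4-methoxyphenyl, 2-chlorophenyl and thiophen-2-yl, cannot be separated in this assay, and all aromatic exchanges at this position so far stay within the scatter. No accompanying measurement bears on this result, and it offers no explanation for it.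

On these data alone, whether a non-aromatic group on this carbon, such as cyclohexyl or a longer alkyl chain, or a phenyl ring carrying a carboxylic acid or an amine, would lift the read-out beyond the scatter remains open. Also open, as far as these compounds go, is whether a change elsewhere on the shared core, such as replacing the nitrile or the group on the ring nitrogen, would move it.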